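Swapping chloro for carboxy: expected gain in solubility

A few compounds are considered here, and "the series" means these few. Any claim that something is new, unique, unknown or untested is made for them only; others in the source may bear on it.

Within the data shown here, compound 1 `Cn1cc(-c2cnc3[nH]cc(-c4ccc(Cl)cc4)c3c2)cn1` has the lower of the two solubility values measured so far. In a physicochemical assay for solubility, read by LC-MS, in phosphate buffer, measured as thermodynamic solubility, with a stated time of 24 h, at pH 7.4 (a higher number here means a more soluble compound, a lower number a less soluble compound), compound 1 gives 800 nM, whereas compound 2 `COc1cccc(-c2c[nH]c3ncc(-c4cnn(C)c4)cc23)c1` gives 18000 nM, a difference well beyond the usual scatter. Compound 3 `Cn1cc(-c2cnc3[nH]cc(-c4ccc(C(=O)O)cc4)c3c2)cn1` keeps the core of compound 1 and changes one position: carboxy in place of chloro on an aromatic carbon. Among the measured compounds shown here, no measured pair shows this exact change, so its effect must be estimated. The expected step from compound 1 to compound 3 is a rise in this assay of about a 50-fold higher number from compound 1 to compound 3 (1.70 log units; beyond the scatter), clearly beyond the scatter. Compound 3 is therefore expected to reach roughly 40000 nM, within a range of 8000 nM to 200000 nM.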

Compound 3, solubility: 850000 nM
Compound 3: middle estimate off by 21-fold (1.33 log units), on the low side; measured number above the stated range.
By their numbers in this assay, from the lowest: compound 1; then compound 2; then compound 3.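

Carboxy in place of chloro on this aromatic carbon, para to a large group, gives a 1100-fold higher number from compound 1 to compound 3 (3.03 log units; beyond the scatter) in this assay. Among these compounds, this is the first measured pair that differs in one place only, and it shows that this single position can shift the number by a very large amount. Nothing measured here explains the size of this step.

From the compounds shown here alone, whether another group on the same aromatic carbon, such as an amine or an amide, would give a step of similar size remains open.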